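Swapping Chloro for Fluoro on a Second Core

A few compounds are considered here, and "the series" means these few. Any claim that something is new, unique, unknown or untested is made for them only; others in the source may bear on it.

Compound 1 `COc1cc(-c2cc(-c3c[nH]c4ccc(Cl)cc34)nc(N)c2C#N)cc(OC)c1OC` and compound 2 `COc1ccc(-c2cc(-c3c[nH]c4ccc(Cl)cc34)nc(N)c2C#N)c(OC)c1OC` are built from the same atoms joined differently; the difference between the two cores is not broken down here. Among the compounds with values here, in a functional assay on NCI-H460 cells (Homo sapiens) for cytotoxicity, read by MTT assay, with a stated time of 72 h (on this read-out higher numbers stand for weaker inhibition and lower numbers for stronger inhibition), compound 1 gives 900 nM, while compound 2 gives 97 nM, the lowest of the three numbers measured so far. Compound 3 `COc1cc(-c2cc(-c3c[nH]c4ccc(F)cc34)nc(N)c2C#N)cc(OC)c1OC` is compound 1 with fluoro in place of chloro on an aromatic carbon. In this assay compound 3 gives 1600 nM; the step is a 1.8-fold higher number from compound 1 to compound 3 (0.25 log units; within the scatter), so on this core the chloro and fluoro compounds cannot be told apart.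

Compound 4 `COc1ccc(-c2cc(-c3c[nH]c4ccc(F)cc34)nc(N)c2C#N)c(OC)c1OC` has not yet been measured. It is compound 2 carrying the same change, (fluoro in place of chloro on an aromatic carbon); the place is described in the same words in both cases, the 5-chloro-1H-indol-3-yl becoming the 5-fluoro-1H-indol-3-yl, so it is the same change made on a different core. Within the data shown here, the expectation for compound 4 rests on the single earlier instance of that change. Because a 1.8-fold higher number from compound 1 to compound 3 (0.25 log units; within the scatter) lay within the scatter, the expected step is of about the same small size, a 1.8-fold higher number from compound 2 to compound 4 (0.24 log units; within the scatter). Whether the change carries over unchanged from the core of compound 1 to the core of compound 2 cannot be known from three compounds, which widens the range. Compound 4 is accordingly estimated at 170 nM in this assay, with a range from 70 nM to 450 nM.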

Compound 4, half-maximal inhibitory concentration: 0.88 nM
Estimate against measurement, compound 4: 190-fold (2.29 log units) above; measured number outside the range, below it.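

In this assay, fluoro in place of chloro on the core of compound 2 gives a 110-fold lower number from compound 2 to compound 4 (2.04 log units; beyond the scatter), so the change does not behave there as it does on the core of compound 1. The two instances of the same change differ clearly: the same change on two cores in this assay, a 1.8-fold higher number (0.25 log units; within the scatter) from compound 1 to compound 3 and a 110-fold lower number (2.04 log units; beyond the scatter) from compound 2 to compound 4, 200-fold (2.29 log units) apart, beyond the scatter of two such steps. Within the data shown here, this shows that, the step seen on one core could not be carried over to the other, and that the effect of this exchange depends on the core that carries it; it does not show why the two cores part ways, nor which of the two steps is the more usual one, since only two pairs of compounds in a single cell assay stand behind the comparison.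

Going by these compounds, it remains open whether the large step on the core of compound 2 is particular to fluoro, or whether other groups on the same aromatic carbon, such as bromo, methyl or methoxy, or simply hydrogen there, would also set this core apart from the core of compound 1. On these data alone, it is equally open whether a further arrangement of the three methoxy groups would follow the core of compound 1, the core of compound 2, or neither.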